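This account rests on a few compounds, and the source may have more. Where it says the series, first, only, none or still open, it means among the compounds named here.

Working notes on the series. Compound 1 `CCOC(=O)C1CCN(Cn2nc(Cc3ccc(SC)cc3)oc2=S)CC1` gives 57.4% in a functional assay on the whole organism (strain Wister albino) for inhibition, with Rattus norvegicus as the target, read by paw edema, with stated times of 30 min and 3 h, at a dose of 10 mg/kg by the oral route; a lower number here means less inhibition, a higher number more inhibition at the dose given (going by the name of the read-out). Compound 2 `COc1ccc(N2CCN(Cn3nc(C(C)c4ccc(CC(C)C)cc4)oc3=S)CC2)cc1` gives 42.6% in this assay. Compound 3 `CSc1ccc(Cc2nn(CN3CCN(c4ccc(Cl)cc4)CC3)c(=S)o2)cc1` gives 71.1% in this assay, and on the three numbers shown compound 3 stands highest: the nearest of the other two is compound 1, whose number lies lower by a gap beyond the usual scatter, and the furthest is compound 2, whose number lies lower by a gap that is also beyond the scatter. For the measured compounds named here, no pair among the measured compounds differs in only one place, so no measured step of the kind that follows exists here.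

Compound 4 `CSc1ccc(Cc2nn(CN3CCN(c4ccc([N+](=O)[O-])cc4)CC3)c(=S)o2)cc1` is the next to be measured in this assay. Relative to compound 3 the change is nitro in place of chloro on an aromatic carbon; the rest of the molecule is unchanged. Going by the values given here, since no measured step exchanges one group on that aromatic carbon for another, the size of the step is not known from the data. On that basis the step from compound 3 to compound 4 is expected to be small, a number 6.1 percentage points lower from compound 3 to compound 4 (within the scatter), not clearly beyond the scatter, and leaning if anywhere slightly downward. Compound 4 is therefore estimated at 65% in this assay, within a range of 50% to 78%.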

Compound 4, a percentage reported as inhibition, in the whole organism at one dose (the size of the read-out at that dose, not a potency): 56.6%
Estimate against measurement, compound 4: 8.4 percentage points above; the range from low to high includes it.
By their numbers in this assay, from the lowest: compound 2; then compounds 4 and 1 (each within the scatter of the next); then compound 3.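

In this assay, for the compounds shown here, the aromatic carbon para to a large group is not indifferent to what it carries: nitro in place of chloro gives a number 14.5 percentage points lower from compound 3 to compound 4 (beyond the scatter) and so supplies the first measured single-place step. The earlier compounds shown here could not show this, as none of them formed a pair differing in only one place, so the size of any exchange on this carbon was unknown until now. The exchange replaces one heavy atom with three and adds two hydrogen-bond acceptors, but nothing measured links either count to the lower number, and the step stands as a description only.

The compounds shown leave open how other groups on this aromatic carbon would rank against chloro and nitro, for instance an amine, a carboxylic acid or a plain hydrogen. Going by these compounds alone, with only one step at this position, read on one background, it also remains open whether the same exchange would give a step of similar size and direction with the rest of the molecule changed.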